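The source may report more compounds than this note shows. Statements on the series, on what has been measured and on what is new or still open speak of the compounds shown alone.

Compound 1 `CC(Oc1ccccc1Br)C1=NCCN1` stands lowest of the three numbers in a functional assay on CHO cells for agonist activity at Alpha-2B adrenergic receptor (Homo sapiens); on this read-out lower numbers stand for an effect already at smaller amounts and higher numbers for an effect only at larger amounts of compound: compound 1 gives 316 nM. Its nearest neighbour is compound 3 `C=CCc1cccc(CC=C)c1OC(C)C1=NCCN1`, which in this assay gives 501 nM, a gap within the scatter, so no order between compound 1 and compound 3 can be read. Among the compounds with values here, the furthest is compound 2 `CCc1ccccc1OC(C)C1=NCCN1`, which in this assay gives 10000 nM; the step of a 32-fold higher number from compound 1 to compound 2 (1.50 log units; beyond the scatter) is the only one-place change measured here, and it is large.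

Compound 4 `CC(Oc1ccccc1S(C)(=O)=O)C1=NCCN1` has not yet been measured. It differs from compound 1 in one place: methylsulfonyl in place of bromo on an aromatic carbon. Within the data shown here, the one measured step that bears on a change at this aromatic carbon is a 32-fold higher number from compound 1 to compound 2 (1.50 log units; beyond the scatter), where bromo gave way to ethyl and the number rose far beyond the scatter. Among the measured compounds shown here, no measured step puts a methylsulfonyl, or any group carrying hydrogen-bond acceptors, on that aromatic carbon, so its direction cannot be read from a like-for-like precedent; compound 3, without bromo, sits within the scatter of compound 1, so loss is not certain. Weighing the one direct precedent, a rise in this assay is expected for compound 4, of about a 9.5-fold higher number from compound 1 to compound 4 (0.98 log units; beyond the scatter), with wide uncertainty. The estimate for compound 4 in this assay is 3000 nM, within a range from 500 nM to 20000 nM.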

Compound 4, half-maximal effective concentration: 10000 nM
Compound 4: the middle estimate sits 3.3-fold (0.52 log units) below what was measured; measured number inside the range.
By their numbers in this assay, from the lowest: compounds 1 and 3 (each within the scatter of the next); then compounds 2 and 4 (each within the scatter of the next).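

Replacing bromo with methylsulfonyl on this aromatic carbon gives a 32-fold higher number from compound 1 to compound 4 (1.50 log units; beyond the scatter) in this assay, so a second replacement, and not only ethyl, produces a large step away from compound 1. Between the two replacements there is no change at the digits printed from compound 2 to compound 4 (within the scatter), which means that this assay does not separate methylsulfonyl, with its 2 hydrogen-bond acceptors, from ethyl at this position, and the presence of those acceptors brings no measurable difference between the two. Of the three groups compared directly on this carbon, bromo alone goes with the lower number, and no measured evidence is available to account for that.

Going by these compounds, whether a halogen such as chloro or fluoro, or a group such as methoxy or an amine, on this aromatic carbon would stay with bromo or join ethyl and methylsulfonyl remains open. Also open, on these data alone, is whether bromo would keep its number on another carbon of the same aromatic ring, and whether a methylsulfonyl placed there would show the same large step.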